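Swapping the aryl ether on a lactone ester

This account rests on a few compounds, and the source may have more. Where it says the series, first, only, none or still open, it means among the compounds named here.

Measured so far in a functional assay on HeLa cells (Homo sapiens) for cytotoxicity, read by sulforhodamine B assay, with a stated time of 72 h; a higher number here means a weaker inhibitor, a lower number a stronger inhibitor:
- compound 1, `C=C1C(=O)O[C@@H]2CC(C)=C([C@@H](C)CCCOC(C)=O)[C@@H](OC(=O)CN3CCCC3)[C@H]12`, gives 12700 nM
- compound 2, `C=C1C(=O)O[C@@H]2CC(C)=C([C@@H](C)CCCOC(C)=O)[C@@H](OC(=O)COc3ccc(C(C)=O)cc3)[C@H]12`, gives 43900 nM
- compound 3, `C=C1C(=O)O[C@@H]2CC(C)=C([C@@H](C)CCCOC(C)=O)[C@@H](OC(=O)COc3ccc([N+](=O)[O-])cc3[N+](=O)[O-])[C@H]12`, gives only a limit, > 100000 nM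

Compound 3 stands at the weak end of the three. Within the data shown here, its value is not a number but a limit of the assay; it is the one value among the three that sits at the limit of > 100000 nM in this assay, at which 1 of the 3 values shown sits.

Compound 4, `C=C1C(=O)O[C@@H]2CC(C)=C([C@@H](C)CCCOC(C)=O)[C@@H](OC(=O)COc3cccc4[nH]nnc34)[C@H]12`, differs from compound 3 in a single place: a group of 9 heavy atoms (6 carbon, 3 nitrogen; one five-membered aromatic ring with 3 hetero atoms, one six-membered aromatic ring of carbon only) in place of a group of 12 heavy atoms (6 carbon, 2 nitrogen, 4 oxygen; one six-membered aromatic ring of carbon only), on an oxygen on a saturated carbon.

Among the measured compounds shown here, two measured steps bear on this change, both at the same position of the shared core. The first is a 3.5-fold higher number from compound 1 to compound 2 (0.54 log units; beyond the scatter). The second is an at least 2.2-fold higher number from compound 2 to compound 3 (0.35 log units; beyond the scatter). Each change of the group on this oxygen so far has given a higher number, and the last one ran into the limit. For the measured compounds named here, because compound 3 is known only through (the limit of > 100000 nM in this assay, at which 1 of the 3 values shown sits), the true size of any step from it cannot be fixed; the group entering in compound 4 is smaller and carries a hydrogen-bond donor, but no measured step tells what that does here.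

Compound 4 is therefore expected at 60000 nM, between 15000 nM and 200000 nM. That estimate means an at least 1.6-fold lower number from compound 3 to compound 4 (0.22 log units; that floor lies within the scatter), an expected change not clearly beyond the scatter, with a real chance that only a limit is reported again.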

Compound 4, half-maximal inhibitory concentration: 23000 nM
The estimate for compound 4 lay 2.6-fold (0.42 log units) above the measured number, and the stated range covers the measured number.
By their numbers in this assay, from the lowest: compounds 1, 4 and 2 (each within the scatter of the next, the first and the last beyond it). At a limit, above all of these: compound 3.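

In this assay, a change of the group on this oxygen can also lower the number: the group with one five-membered aromatic ring with 3 hetero atoms and one six-membered aromatic ring of carbon only, in place of 2,4-dinitrophenyl, gives an at least 4.3-fold lower number from compound 3 to compound 4 (0.63 log units; beyond the scatter), whereas both earlier steps at this position went to a higher number. Compound 3 has a limit rather than a number, which leaves only a floor for the size of this step: the limit of > 100000 nM in this assay, at which 1 of the 4 values shown sits. The other two new steps, a 1.9-fold lower number from compound 2 to compound 4 (0.28 log units; within the scatter) and a 1.8-fold higher number from compound 1 to compound 4 (0.26 log units; within the scatter), both lie within the scatter, leaving the entering group indistinguishable in this assay from 4-acetylphenyl on the same oxygen and from pyrrolidin-1-yl on the saturated chain carbon, even though those two compounds differ beyond the scatter.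

The compounds shown do not reveal whether the lower number comes from the loss of the two nitro groups or from the entering ring system, and an unsubstituted phenyl on this oxygen would bear on that question. Going by these compounds, how a morpholine ring in place of pyrrolidin-1-yl would read also stays open.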